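The source may report more compounds than this note shows. Statements on the series, on what has been measured and on what is new or still open speak of the compounds shown alone.

The shared core of compound 1 `O=C(O)c1cn(Cc2ccc(-n3cccn3)cc2)c2cc(N3CC4CNCC4C3)c(F)cc2c1=O` and compound 2 `O=C(O)c1cn(Cc2ccc(-c3ccccc3)cc2)c2cc(N3C[C@H]4CCNC[C@H]4C3)c(F)cc2c1=O` is a quinolone acid with a fluorine and a bicyclic amine on one side and a benzyl group on the ring nitrogen. In an assay on isolated protein for inhibition of DNA topoisomerase 1 (Homo sapiens), with a stated time of 15 min (on this read-out lower numbers stand for stronger inhibition and higher numbers for weaker inhibition), compound 1 gives 173000 nM, and compound 2 gives 61000 nM, the lowest of the two numbers, and the gap to compound 1 lies beyond the scatter. Compound 3 `O=C(O)c1cn(Cc2ccc(-n3cccn3)cc2)c2cc(N3C[C@H]4CCNC[C@H]4C3)c(F)cc2c1=O` is compound 2 with one change: 1H-pyrazol-1-yl in place of phenyl on an aromatic carbon. Going by the values given here, no measured pair differs in only this place, so the step has to be guessed; compound 1 carries the same pyrazolyl group but also a different amine, and is weaker. A modest weakening beyond the scatter is expected, a 1.8-fold higher number from compound 2 to compound 3 (0.26 log units; within the scatter), because compound 1 gives 173000 nM. Compound 3 is therefore estimated at 110000 nM, with a likely range from 50000 nM to 250000 nM.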

Compound 3, half-maximal inhibitory concentration: 31300 nM
Compound 3: middle estimate off by 3.5-fold (0.55 log units), on the high side; measured number outside the range, below it.
By their numbers in this assay, from the lowest: compounds 3 and 2 (each within the scatter of the next); then compound 1.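

In this assay, 1H-pyrazol-1-yl in place of phenyl gives a 1.9-fold lower number from compound 2 to compound 3 (0.29 log units; within the scatter) and so lies within the scatter, which means that at this place, para to a large group, a five-membered aromatic ring with two nitrogens can stand in for a six-membered ring of carbon only without a change that this assay can resolve. Going by these compounds alone, with the 1H-pyrazol-1-yl group held fixed, the exchange of the bicyclic amine gives a 5.5-fold lower number from compound 1 to compound 3 (0.74 log units; beyond the scatter) and lies beyond the scatter, so of these two single changes only the one in the amine can be read as a real difference. Nothing measured here speaks to why either step has the size it has.

On these data alone, it remains open how a pyridyl ring or a carboxylic acid would read at this place. As far as these compounds go, it is also open whether phenyl combined with the amine of compound 1 would behave as the 1H-pyrazol-1-yl group does.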